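A few compounds are considered here, and "the series" means these few. Any claim that something is new, unique, unknown or untested is made for them only; others in the source may bear on it.

Compound 3, `COc1ccc2nc(C)cc(OCC(=O)Nc3ccc(F)cc3)c2c1`, is one of three amides built on the shared core. In a toxicity assay on HepG2 cells (Homo sapiens) for inhibition, read by CellTiter-Glo, with a stated time of 48 h (a lower number here means a stronger inhibitor, a higher number a weaker inhibitor), compound 3 gives 63100 nM. Compound 1, `COc1ccc2nc(C)cc(OCC(=O)Nc3cccc(C)c3)c2c1`, gives 39800 nM in this assay, and the gap a 1.6-fold higher number from compound 1 to compound 3 (0.20 log units; within the scatter) leaves the two undistinguished. Compound 2, `COc1ccc2nc(C)cc(OCC(=O)Nc3cc(C)ccc3C)c2c1`, reaches only a limit of this assay, > 100000 nM. Of the two numbers shown, compound 3 carries the higher one, with compound 1 as its nearest neighbour.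

The step to compound 4, `COc1ccc2nc(C)cc(OCC(=O)Nc3c(C)cncc3C)c2c1`, is 3,5-dimethylpyridin-4-yl in place of 4-fluorophenyl on an amide-type nitrogen. For the measured compounds named here, two measured steps bear on it. The step of an at least 2.5-fold higher number from compound 1 to compound 2 (0.40 log units; beyond the scatter) shows that methyl placed on the aromatic ring of the amide substituent moves the number up, and the limit of > 100000 nM in this assay, at which 1 of the 3 values shown sits, marks where compound 2 then sits. The step of an at least 1.5-fold lower number from compound 2 to compound 3 (0.19 log units; that floor lies within the scatter) runs the other way, but its floor stays within the scatter. The 3,5-dimethylpyridin-4-yl group of compound 4 again brings methyl onto that ring, so a higher number than for compound 3 is expected, with a real chance that only a limit is returned. The expected step is a 1.4-fold higher number from compound 3 to compound 4 (0.15 log units; within the scatter). Compound 4 is therefore estimated at 90000 nM, in the range 35000 nM to 250000 nM.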

Compound 4, half-maximal inhibitory concentration: 12600 nM
Estimate against measurement, compound 4: 7.1-fold (0.85 log units) above; measured number below the stated range.
By their numbers in this assay, from the lowest: compound 4; then compounds 1 and 3 (each within the scatter of the next). At a limit, above all of these: compound 2.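

In this assay, for the compounds shown here, 3,5-dimethylpyridin-4-yl on the amide-type nitrogen gives the only steps at this position to a lower number that lie beyond the scatter: a 5.0-fold lower number from compound 3 to compound 4 (0.70 log units; beyond the scatter), a 3.2-fold lower number from compound 1 to compound 4 (0.50 log units; beyond the scatter) and an at least 7.9-fold lower number from compound 2 to compound 4 (0.89 log units; beyond the scatter). Methyl on the ring of the amide substituent therefore does not go with a higher number throughout, since compound 2 follows that direction and compound 4 goes against it. The last of these steps has only a floor, as compound 2 stands at a limit and not at a number: the limit of > 100000 nM in this assay, at which 1 of the 4 values shown sits.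

From the compounds shown here alone, in compound 4 the ring hetero atom and the two methyl groups enter together, so their separate shares stay open. A pyridin-4-yl group without methyl would separate them, and a morpholine or a carboxylic acid on the ring would test how far the trend extends.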